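A sulfonamide methyl removed from compound 3

The compounds below may be only part of what the source reports. "The series", "measured", "known", "first", "only" and "open" are said of these compounds alone.

In a physicochemical assay for solubility, in phosphate buffer, measured as kinetic solubility, with a stated time of 24 h, at pH 6.5 (on this read-out lower numbers stand for lower solubility and higher numbers for higher solubility), compound 1 `CC(C)Oc1cc(Oc2ccc(S(C)(=O)=O)cc2)cc(-c2cncc(=O)[nH]2)c1` gives 118000 nM and compound 2 `CC(C)Oc1cc(Oc2ccc(S(C)(=O)=O)cc2)cc(-c2ncc(Cl)c(=O)[nH]2)c1` gives 24000 nM. Compound 3 `Cc1cnc(-c2cc(Oc3ccc(S(=O)(=O)N(C)C)cc3)cc(O[C@@H](C)CO)c2)[nH]c1=O` gives 197000 nM, within the scatter of compound 1 and well clear of compound 2. Compound 4 `CNS(=O)(=O)c1ccc(Oc2cc(O[C@@H](C)CO)cc(-c3ncc(C)c(=O)[nH]3)c2)cc1` differs from compound 3 by hydrogen in place of methyl on a sulfonamide nitrogen. Among the measured compounds shown here, the only measured step, a 4.9-fold lower number from compound 1 to compound 2 (0.69 log units; beyond the scatter), is modest but lies elsewhere in the structure, so it gives no size to carry over. With no measured guide for this change, the estimate stays anchored on compound 3 at 197000 nM, and no step beyond the scatter is expected. The expected change is a 1.4-fold lower number from compound 3 to compound 4 (0.15 log units; within the scatter). Compound 4 is estimated at 140000 nM, with an expected range of 55000 nM to 260000 nM.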

Compound 4, solubility: 104000 nM
The estimate for compound 4 lay 1.3-fold (0.13 log units) above the measured number; low and high end bracket the measured number.
By their numbers in this assay, from the lowest: compound 2; then compounds 4, 1 and 3 (each within the scatter of the next).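

In this assay, the change on the sulfonamide nitrogen gives a 1.9-fold lower number from compound 3 to compound 4 (0.28 log units; within the scatter) and so stays within the usual scatter. Among the compounds shown here, on this single pair, dimethylsulfamoyl and methylsulfamoyl cannot be told apart, and this position shows no step that can be given a size. Nothing measured here bears on the reason for this result.

Still open, as far as these compounds go, is whether a primary sulfonamide, with hydrogen in place of both methyls, would give a step beyond the scatter. The same question stands for a longer chain such as ethyl on that nitrogen, or a carboxylic acid in place of the sulfamoyl group.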